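The compounds below may be only part of what the source reports. "The series", "measured", "known", "first", "only" and "open" are said of these compounds alone.

Measured compounds in a toxicity assay on MDCK cells (Canis lupus familiaris) for cytotoxicity, read by CCK-8 assay, with a stated time of 48 h; on this read-out higher numbers stand for lower toxicity in this test and lower numbers for higher toxicity in this test:
compound 1, `O=C(NNc1c(Br)cccc1Br)c1ccc(OCC(F)(F)F)cc1`: > 100000 nM
compound 2, `CCOc1ccc(C(=O)NNc2c(Cl)cccc2Cl)cc1`: > 100000 nM
compound 3, `CN(C)c1ccc(C(=O)NNc2c(Cl)cccc2Cl)cc1`: > 100000 nM

Each of these three values is a limit of the assay and not a number. Compound 1 therefore stands only at the limit, and no order among the three compounds can be read. Among the measured compounds shown here, the one single-point change that has been measured, a step that the two limits leave unreadable from compound 2 to compound 3, exchanges the group on the same aromatic carbon that is varied here, but its size cannot be read because both of its ends sit at the limit of > 100000 nM in this assay, at which 3 of the 3 values shown sit.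

Compound 4, `O=C(O)c1ccc(C(=O)NNc2c(Br)cccc2Br)cc1`, differs from compound 1 in one place: carboxy in place of 2,2,2-trifluoroethoxy on an aromatic carbon. For the measured compounds named here, no readable step bears on a carboxy group or on a 2,2,2-trifluoroethoxy group in this assay; the only comparable exchange, from ethoxy to dimethylamino, stayed at the limit on both sides. The expectation is thus no step beyond the scatter, with compound 4 again most likely reported only as a limit. The expected step from compound 1 to compound 4 is a step that the limit leaves unreadable from compound 1 to compound 4. For compound 4 the estimate in this assay is 150000 nM, ranging from 60000 nM to 500000 nM.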

Compound 4, half-maximal cytotoxic concentration: > 100000 nM
Compound 4 ended at the assay's limit (the forecaster's own chance of this, stated with the estimate: 85%); the middle value lies beyond the limit too.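

Compound 1 and compound 4 both stand at a limit and not at a number in this assay, so carboxy in place of 2,2,2-trifluoroethoxy gives no readable step: the limit of > 100000 nM in this assay, at which 4 of the 4 values shown sit.

The compounds shown leave open at what concentration any of them becomes toxic to these cells.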